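Notes on compound 3: a smaller aromatic ring replaces the aryl group

The source may hold more compounds than are shown below. What is called first, only, known or untested is meant among the compounds shown, and "the series" means these compounds.

Compound 1 `CCOC(=O)c1cnc(-n2nc(C)cc2C)nc1NN1C(=O)C=C(C)C1=O`: 10000 nM
Compound 2 `CCOC(=O)c1cnc(-c2ccc(C(F)(F)F)cc2)nc1NN1C(=O)C=C(C)C1=O`: 400 nM

In a functional assay on Jurkat cells for inhibition of nuclear factor NF-kappa-B complex (Homo sapiens) (on this read-out lower numbers stand for stronger inhibition and higher numbers for weaker inhibition), compound 1 gives 10000 nM and compound 2 gives 400 nM, the lowest of the two numbers. Among the measured compounds shown here, the only measured step, a 25-fold lower number from compound 1 to compound 2 (1.40 log units; beyond the scatter), exchanged one aromatic ring for another on the same carbon of the shared core. Compound 3 `CCOC(=O)c1cnc(-c2ccc(Cl)s2)nc1NN1C(=O)C=C(C)C1=O` differs from compound 2 by 5-chlorothiophen-2-yl in place of 4-(trifluoromethyl)phenyl on an aromatic carbon. For the measured compounds named here, no measured step exchanges a carbon-only aromatic ring for a five-membered ring with one hetero atom, so its size is unknown; a step within or only modestly beyond the scatter is expected, a 1.5-fold higher number from compound 2 to compound 3 (0.18 log units; within the scatter). Compound 3 is estimated at 600 nM, with a range of 200 nM to 2500 nM.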

Compound 3, half-maximal inhibitory concentration: 300 nM
Compound 3: the middle estimate sits 2.0-fold (0.30 log units) above what was measured, and the stated range covers the measured number.
By their numbers in this assay, from the lowest: compounds 3 and 2 (each within the scatter of the next); then compound 1.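

At this position, between two ring nitrogen atoms, 5-chlorothiophen-2-yl is matched with 4-(trifluoromethyl)phenyl: a 1.3-fold lower number from compound 2 to compound 3 (0.12 log units; within the scatter) in this assay shows that a six-membered carbon-only aromatic ring is not required here. The 3,5-dimethyl-1H-pyrazol-1-yl compound now stands apart from two different rings, with a 33-fold lower number from compound 1 to compound 3 (1.52 log units; beyond the scatter) matching the size of the earlier step. Nothing available explains why these two rings match or why compound 1 differs.

Open, from the compounds shown here alone, is whether the chlorine on the thiophene contributes to the value. Also open, going by these compounds, is how a saturated ring or an amine at this position would compare.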